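This account rests on a few compounds, and the source may have more. Where it says the series, first, only, none or still open, it means among the compounds named here.

Of the compounds shown here, two of a shared core have been measured in a functional assay on BGC-823 cells (Homo sapiens) for antiproliferative activity, read by MTT assay, with a stated time of 48 h; a higher number here means a weaker inhibitor, a lower number a stronger inhibitor. Compound 1 `Fc1ccc(CSc2nnc(-c3ccc4c(c3)OCCO4)o2)cc1` gives 28700 nM in this assay, while compound 2 `O=[N+]([O-])c1cccc(CSc2nnc(-c3ccc4c(c3)OCCO4)o2)c1` gives 23700 nM; compound 1 holds the higher of the two numbers, but the two values lie within the scatter of each other, so no order between them can be read. Compound 3 `Cc1ccc(CSc2nnc(-c3ccc4c(c3)OCCO4)o2)cc1`, not yet measured, differs from compound 1 in one place: methyl in place of fluoro on an aromatic carbon. Among the compounds with values here, with only two measurements, neither of which separates from the other, nothing in this set shows how an exchange of this kind moves the number; the expectation is therefore a step of about a 1.1-fold lower number from compound 1 to compound 3 (0.04 log units; within the scatter), that is, none beyond the scatter. On that basis compound 3 is estimated to give 26000 nM in this assay, with a range from 10000 nM to 70000 nM.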

Compound 3, half-maximal inhibitory concentration: 31600 nM
Estimate against measurement, compound 3: 1.2-fold (0.08 log units) below; measured number inside the range.
By their numbers in this assay, from the lowest: compounds 2, 1 and 3 (each within the scatter of the next).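

In this assay, within the data shown here, putting methyl in place of fluoro on the aromatic carbon para to a large group gives a 1.1-fold higher number from compound 1 to compound 3 (0.04 log units; within the scatter), the first step in this set between compounds that differ in one place. At this position, 4-fluorobenzyl and 4-methylbenzyl therefore cannot be told apart by this read-out, although the exchange is a narrow one: each group has one heavy atom, no ring, no hydrogen-bond donors or acceptors and no net charge. Nothing available bears on why the step stays so small.

On these data alone, whether a larger or charged group on this aromatic carbon, such as an amine, a carboxylic acid or a longer alkyl chain, would move the number beyond the scatter remains open. So does whether the same exchange would behave alike on another carbon of this ring.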